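The source may report more compounds than this note shows. Statements on the series, on what has been measured and on what is new or still open speak of the compounds shown alone.

Compound 1, `COc1cc(-c2cc(/C=C/C(=O)c3ccc(N)cc3)[nH]n2)cc(OC)c1OC`, was tested in a functional assay on M14 cells (Homo sapiens) for cytotoxicity, read by sulforhodamine B assay, with a stated time of 48 h, tested at 1 uM (a higher number here means a weaker effect of the compound at the concentration tested, a lower number a stronger effect), where compound 1 gives 90%. Compound 2, `COc1ccc(-c2cc(/C=C/C(=O)c3ccc(OC)c(OC)c3)[nH]n2)cc1`, gives 97% in this assay, and compound 3, `COc1cc(-c2cc(/C=C/C(=O)c3ccc(Cl)c(Cl)c3)[nH]n2)cc(OC)c1OC`, gives 107%. Of the three numbers that of compound 1 is the lowest; the gap to compound 2 lies within the scatter, while the gap to compound 3 lies beyond it, as the step of a number 17 percentage points higher from compound 1 to compound 3 (beyond the scatter) shows. Compound 4, `COc1ccc(-c2cc(/C=C/C(=O)c3ccc(N)cc3)[nH]n2)cc1OC`, differs from compound 1 by hydrogen in place of methoxy on an aromatic carbon. Among the compounds with values here, no measured step concerns this change, and the one step on record, a number 17 percentage points higher from compound 1 to compound 3 (beyond the scatter), alters a different part of the shared core. Compound 1 and compound 2 differ in two places, so their values only show two numbers within the scatter of each other. A step in this assay of no more than the scatter is therefore expected, a number 3 percentage points higher from compound 1 to compound 4 (within the scatter). Compound 4 is estimated to give 93%, between 80% and 106%.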

Compound 4, a percentage reported as activity, at one concentration (the size of the read-out at that concentration, not a potency): 101%
Beside the measured number, compound 4's estimate is 8 percentage points below it; the range from low to high includes it.
By their numbers in this assay, from the lowest: compounds 1, 2, 4 and 3 (each within the scatter of the next, the first and the last beyond it).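

In this assay, hydrogen in place of methoxy on this aromatic carbon gives a number 11 percentage points higher from compound 1 to compound 4 (beyond the scatter), a modest weakening of the effect at the concentration tested. Within the data shown here, this is the first step on record at this position, and it shows that the methoxy group here cannot be removed without a change beyond the scatter. Nothing available explains this step. As far as these compounds go, whether a hydroxy or an ethoxy group on this carbon would behave like methoxy stays open. So does whether the step would recur with 3,4-dichlorophenyl on the carbonyl carbon.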